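Working notes on the series ahead of compound 4

The compounds below may be only part of what the source reports. "The series", "measured", "known", "first", "only" and "open" are said of these compounds alone.

Of the compounds shown here, three have been measured in a functional assay on HeLa cells (Homo sapiens) for cytotoxicity, read by MTT assay, with a stated time of 48 h; a lower number here means a stronger inhibitor, a higher number a weaker inhibitor. Compound 1 `CCOC(=O)c1c(-c2c(Cl)c3cc(C)ccc3oc2=O)nn(-c2cccc(C)c2)c1C(=O)OCC` gives 115000 nM. Compound 2 `COC(=O)c1c(-c2cc3ccccc3oc2=O)nn(-c2cccc(C)c2)c1C(=O)OC` gives 45000 nM. Compound 3 `CCOC(=O)c1c(-c2cc3ccccc3oc2=O)nn(-c2ccc(C)c(C)c2)c1C(=O)OCC` gives 50000 nM. Among these, compound 2 shows the lowest number, but compound 3 sits within the scatter of it, so no order between the two can be stated; only compound 1 lies beyond the scatter, with the higher number. For the measured compounds named here, no pair among the three differs in a single place, so no step has been isolated.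

Compound 4 `COC(=O)c1c(-c2cc3ccccc3oc2=O)nn(-c2ccc(Br)cc2)c1C(=O)OC` is the next to be measured in this assay . It differs from compound 2 by 4-bromophenyl in place of 3-methylphenyl on an aromatic nitrogen; in words, 4-bromophenyl in place of 3-methylphenyl on an aromatic nitrogen. Going by the values given here, nothing measured so far speaks to a change at that position, since compound 3 carries a different group there and also a different ester. The expected step from compound 2 to compound 4 is therefore set at none beyond the scatter, no change at the digits printed from compound 2 to compound 4 (within the scatter). On that basis compound 4 is estimated at 45000 nM in this assay , with a range from 15000 nM to 135000 nM.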

Compound 4, half-maximal inhibitory concentration: 120000 nM
Beside the measured number, compound 4's estimate is 2.7-fold (0.43 log units) below it; the measured number falls inside the stated range.
By their numbers in this assay, from the lowest: compounds 2 and 3 (each within the scatter of the next); then compounds 1 and 4 (each within the scatter of the next).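

For the compounds shown here, the swap on the aromatic nitrogen is the first single-place change, and in this assay it gives a 2.7-fold higher number from compound 2 to compound 4 (0.43 log units; beyond the scatter), showing that with both methoxycarbonyl groups and the rest of the core held fixed, the group on that nitrogen bears on the read-out, here towards a weaker inhibitor. The computed comparison gives 3-methylphenyl and 4-bromophenyl the same counts of heavy atoms, hydrogen-bond donors and hydrogen-bond acceptors, so those counts do not separate the two groups, yet the change replaces the substituent and moves it on the phenyl ring in one step, and the size of the step cannot be assigned to either alone. No measurement at hand gives a reason for the step.

The compounds shown leave open whether the substituent or its place on the phenyl ring carries the step, a question that 3-bromophenyl or 4-methylphenyl on the same nitrogen would address directly. They also leave open how this position responds to an unsubstituted phenyl, or to a phenyl carrying an amine or a carboxylic acid.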